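Benzyl gives way to 4-cyanophenyl in compound 4

A few compounds are considered here, and "the series" means these few. Any claim that something is new, unique, unknown or untested is made for them only; others in the source may bear on it.

Measured in a functional assay on U-373MG ATCC cells (Homo sapiens) for inhibition, read by MTT assay, with a stated time of 72 h; a lower number here means a stronger inhibitor, a higher number a weaker inhibitor:
compound 1 `CC1(C)CC(NC(=S)Nc2ccc(C#N)cc2)c2cc(F)ccc2O1` gives 11000 nM
compound 2 `COc1cccc(NC(=S)NC2CC(C)(C)Oc3ccc(Br)cc32)c1` gives 66000 nM
compound 3 `CC1(C)CC(NC(=S)NCc2ccccc2)c2cc(Br)ccc2O1` gives 29000 nM

Compound 3 holds the second highest of these three numbers. Among the compounds with values here, compound 4 `CC1(C)CC(NC(=S)Nc2ccc(C#N)cc2)c2cc(Br)ccc2O1` keeps its core but carries 4-cyanophenyl in place of benzyl on an amide-type nitrogen as its one change. Within the data shown here, the only measured step at that place is modest: a 2.3-fold lower number from compound 2 to compound 3 (0.36 log units; beyond the scatter) and it involves 3-methoxyphenyl, not 4-cyanophenyl. Among the measured compounds shown here, no measured step isolates the new group. Compound 1 also carries 4-cyanophenyl, on a core that is not identical, and its value of 11000 nM is lower than the value of compound 3 in this assay on the same scale. A modest move to a lower number is therefore expected. The estimated change is a 2.4-fold lower number from compound 3 to compound 4 (0.38 log units; beyond the scatter) for this pair. Compound 4 is expected at 12000 nM with an estimated range from 5000 nM to 28000 nM in this reading.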

Compound 4, half-maximal inhibitory concentration: 22000 nM
Compound 4: the middle estimate sits 1.8-fold (0.26 log units) below what was measured; the range from low to high includes it.
By their numbers in this assay, from the lowest: compounds 1, 4 and 3 (each within the scatter of the next, the first and the last beyond it); then compound 2.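

In this assay, 4-cyanophenyl in place of benzyl on an amide-type nitrogen gives a 1.3-fold lower number from compound 3 to compound 4 (0.12 log units; within the scatter), so the two groups cannot be told apart here, while 4-cyanophenyl in place of 3-methoxyphenyl gives a 3.0-fold lower number from compound 2 to compound 4 (0.48 log units; beyond the scatter). With 4-cyanophenyl held constant, bromo in place of fluoro on an aromatic carbon gives a 2.0-fold higher number from compound 1 to compound 4 (0.30 log units; within the scatter), which also stays within the usual scatter. No available measurement explains these steps. On these data alone, whether an amine, a carboxylic acid or a longer chain on that nitrogen would shift the number beyond the scatter remains open.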